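Will an ethyl group lift compound 4 off the limit?

The source may hold more compounds than are shown below. What is called first, only, known or untested is meant among the compounds shown, and "the series" means these compounds.

Measured in a functional assay on HeLa cells (Homo sapiens) for antiproliferative activity, read by MTT assay, with a stated time of 48 h; on this read-out higher numbers stand for weaker inhibition and lower numbers for stronger inhibition:
- compound 1 `Cn1cc(-c2cnc3ccc(N)nc3c2)cn1`: > 50000 nM (a limit)
- compound 2 `CC(=O)Nc1ccc2ncc(-c3cnn(C)c3)cc2n1`: > 50000 nM (a limit)
- compound 3 `Cn1cc(-c2cnc3ccc(NC(=O)c4cccnc4)nc3c2)cn1`: > 50000 nM (a limit)

Compound 3 gives > 50000 nM, which is a limit of this assay and not a number. The other two compounds share that position, so all three stand at the limit of > 50000 nM in this assay, at which 3 of the 3 values shown sit. The next compound, compound 4 `CCNc1ccc2ncc(-c3cnn(C)c3)cc2n1`, carries ethyl in place of (pyridin-3-yl)carbonyl on a nitrogen on an aromatic ring, and the count of that change is ethyl in place of (pyridin-3-yl)carbonyl on a nitrogen on an aromatic ring.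

Within the data shown here, three measured steps bear on this change: a step that the two limits leave unreadable from compound 1 to compound 2, a step that the two limits leave unreadable from compound 1 to compound 3 and a step that the two limits leave unreadable from compound 2 to compound 3. None of them has a size that can be read, so they offer no sign of a gain or a loss in potency. Among the measured compounds shown here, nothing measured so far therefore points to a real shift in either direction. The expected result is a number no higher from compound 3 to compound 4 (the limit leaves the size open), with no step beyond the scatter. For compound 4 the estimated value is 50000 nM, with an expected range from 25000 nM to 100000 nM, and most likely only a limit will be reported.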

Compound 4, half-maximal inhibitory concentration: > 50000 nM
Compound 4 ended at the assay's limit; the forecaster's own chance of this, stated with the estimate: 85%; the middle value sits exactly at the limit.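

In this assay compound 4 gives > 50000 nM, which is a limit and not a number, so its steps from compound 1, compound 2 and compound 3 cannot be read. All four compounds stand at the same place: the limit of > 50000 nM in this assay, at which 4 of the 4 values shown sit.

On these data alone, how potent any of these four compounds really is, and whether they differ from one another at all, remains open.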